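Swapping a butyl for a fluorobenzyl on the amine

This account rests on a few compounds, and the source may have more. Where it says the series, first, only, none or still open, it means among the compounds named here.

The shared core carries a nitrogen that bears two chains, and the size of those chains is the only thing that varies here. Compound 1 `CCCCN(CC)c1cc(C)nc2c(-c3cnc(N(C)C)cc3C)c(C)nn12` is measured in an assay on CHO cells for binding affinity to corticotropin-releasing factor receptor 1 (Homo sapiens) (a lower number here means a stronger inhibitor, a higher number a weaker inhibitor), and gives 2.6 nM, the lowest of the two numbers seen so far. Compound 2 `CCCCN(CCCC)c1cc(C)nc2c(-c3cnc(N(C)C)cc3C)c(C)nn12` gives 4.2 nM in this assay, and the step of a 1.6-fold higher number from compound 1 to compound 2 (0.21 log units; within the scatter) lengthens one chain without moving the number beyond the usual spread. Compound 3 `CCN(Cc1ccccc1F)c1cc(C)nc2c(-c3cnc(N(C)C)cc3C)c(C)nn12` changes the other chain instead: 2-fluorophenyl in place of propyl on a saturated chain carbon bound to a nitrogen on an aromatic ring. Among the measured compounds shown here, no measured step swaps a chain for a ring, so the only guide is the step from compound 1 to compound 2, which shows this nitrogen accepting a bulkier group without loss. The change to compound 3 is therefore expected to move the number little, with a modest shift either way remaining possible; the step of a 1.5-fold higher number from compound 1 to compound 3 (0.19 log units; within the scatter) is the expected outcome. Compound 3 is estimated at 4 nM, with a likely range from 1.5 nM to 12 nM.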

Compound 3, inhibition constant: 3.4 nM
Compound 3: the middle estimate sits 1.2-fold (0.07 log units) above what was measured; measured number inside the range.
By their numbers in this assay, from the lowest: compounds 1, 3 and 2 (each within the scatter of the next).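

In this assay, going from butyl to 2-fluorobenzyl on the amine nitrogen gives a 1.3-fold higher number from compound 1 to compound 3 (0.12 log units; within the scatter) and so stays within the usual spread of repeat measurements. Compounds 1 and 2 carried only plain saturated chains on this nitrogen, whereas compound 3 shows that a chain ending in an aromatic ring with a fluorine on it also keeps the number in the same low range. No measurement here bears on why the ring and the plain chain give such similar numbers.

The compounds shown leave open what the fluorine itself contributes, as a plain benzyl on this nitrogen would be needed to separate it from the ring. From the compounds shown here alone, how far this position stretches also remains open, for example to a longer chain ending in a phenyl ring or to a chain carrying an amine or a carboxylic acid.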